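Aminoethyl Amide Replaces the Ester Amide of Compound 3

The compounds below may be only part of what the source reports. "The series", "measured", "known", "first", "only" and "open" are said of these compounds alone.

Compound 3 `CCOC(=O)CN(C)C(=O)c1ccc(C(CC)(CC)c2ccc(OCC(O)C(C)(C)C)c(C)c2)n1CC` gives 210 nM in an assay on HL-60 cells for agonist activity at vitamin D3 receptor (Homo sapiens), read by microscopy, with a stated time of 96 h (on this read-out lower numbers stand for an effect already at smaller amounts and higher numbers for an effect only at larger amounts of compound), the lowest of the two numbers shown. Compound 1 `CC[C@@H](C)[C@H](NC(=O)c1ccc(C(CC)(CC)c2ccc(OCC(=O)C(C)(C)C)c(C)c2)n1CC)C(=O)OC` gives 590 nM in this assay. Compound 2 `CCOC(=O)CN(C)C(=O)c1ccc(C(CC)(CC)c2ccc(OCC(=O)C(C)(C)C)c(C)c2)n1CC` reaches only a limit in this assay, > 50000 nM, which is the limit of > 50000 nM in this assay, at which 1 of the 3 values shown sits. Compound 4 `CCn1c(C(=O)NCCN)ccc1C(CC)(CC)c1ccc(OCC(O)C(C)(C)C)c(C)c1` differs from compound 3 by (2-aminoethyl)amino in place of ((ethoxycarbonyl)methyl)(methyl)amino on a carbonyl carbon. Going by the values given here, two measured steps bear on this change: an exchange of the amide substituent, an at least 84-fold higher number from compound 1 to compound 2 (1.92 log units; beyond the scatter), and the ketone-to-alcohol change, an at least 230-fold lower number from compound 2 to compound 3 (2.37 log units; beyond the scatter). Both were large, so a change at this carbonyl carbon can move the number far, yet neither involved an aminoethyl group, leaving the direction open. Compound 4 is therefore expected to give about 700 nM, between 100 nM and 6000 nM, a step of a 3.3-fold higher number from compound 3 to compound 4 (0.52 log units; beyond the scatter).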

Compound 4, half-maximal effective concentration: 10 nM
For compound 4 the middle estimate is 70-fold (1.85 log units) above the measured one, outside the stated range (below it).
By their numbers in this assay, from the lowest: compound 4; then compound 3; then compound 1. At a limit, above all of these: compound 2.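

In this assay, the amide group on this carbonyl carbon can also lower the number sharply: (2-aminoethyl)amino in place of ((ethoxycarbonyl)methyl)(methyl)amino gives a 21-fold lower number from compound 3 to compound 4 (1.32 log units; beyond the scatter). Going by these compounds alone, the only earlier change at this place, between compounds with the ketone, raised the number. No measurement shown accounts for this gain.

As far as these compounds go, this single change removes the ester and the methyl on the amide nitrogen and adds an amine, so which of these matters stays open. Also open, from the compounds shown here alone, is how a longer chain such as (3-aminopropyl)amino, or a carboxylic acid in place of the amine, would read.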